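A few compounds are considered here, and "the series" means these few. Any claim that something is new, unique, unknown or untested is made for them only; others in the source may bear on it.

Measured so far in an ADME assay on HEK293 cells (Homo sapiens) for cytotoxicity, read by MTT assay, with a stated time of 72 h; a lower number here means a stronger inhibitor, a higher number a weaker inhibitor:

- compound 1 `O=C(CN1CCN(C(=O)c2ccc(Cl)cc2)CC1)N1CCN(CCCc2c[nH]c3ccccc23)CC1`: 98200 nM
- compound 2 `O=C(CN1CCN(C(=O)c2cccc(Cl)c2)CC1)N1CCN(CCCc2c[nH]c3ccccc23)CC1`: 99100 nM

Within the data shown here, compound 2 stands level with compound 1, the only other compound measured, and their two numbers lie within the scatter of each other. The compound still to be measured, compound 3 `O=C(CN1CCN(C(=O)c2cccc(F)c2)CC1)N1CCN(CCCc2c[nH]c3ccccc23)CC1`, carries fluoro in place of chloro on an aromatic carbon, meta to a large group: fluoro in place of chloro on an aromatic carbon.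

Among the measured compounds shown here, one measured step bears on this change: a 1.0-fold higher number from compound 1 to compound 2 (0.00 log units; within the scatter). That step shifted the chloro group to another place on the ring and did not replace it, so it offers only indirect guidance. It does show that this part of the molecule has so far made no visible difference. For the measured compounds named here, no compound with a fluoro group has been measured yet, so a direct comparison is missing.

On this evidence, no change beyond the scatter is expected in this assay, and neither direction is favoured. The expected step is a 1.0-fold higher number from compound 2 to compound 3 (0.00 log units; within the scatter). For compound 3 the estimated value is 100000 nM, with an expected range from 60000 nM to 170000 nM.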

Compound 3, half-maximal inhibitory concentration: 182000 nM
Beside the measured number, compound 3's estimate is 1.8-fold (0.26 log units) below it; the whole stated range lies below it.
By their numbers in this assay, from the lowest: compounds 1, 2 and 3 (each within the scatter of the next).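

In this assay, among these compounds, this is the first step that exchanges the group itself rather than moving it (a 1.8-fold higher number from compound 2 to compound 3 (0.26 log units; within the scatter)), so fluoro in place of chloro, on an aromatic carbon meta to a large group, stays inside the usual scatter. The wider exchange, which alters both the group and its place on the ring (a 1.9-fold higher number from compound 1 to compound 3 (0.27 log units; within the scatter)), also stays inside that scatter, so across these three compounds neither the identity of this group nor its place has shown a real difference. No measurement is available that could explain the size of these steps.

Whether an amine or a carboxylic acid on this aromatic carbon would carry the number beyond the scatter remains open, since chloro and fluoro are the only groups shown on this ring. Among the compounds shown here, also open is whether a change away from this ring, such as a longer chain within the shared core, would matter more than anything seen at this position so far.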